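Series notes: from 2-fluorophenyl to plain phenyl

The compounds below may be only part of what the source reports. "The series", "measured", "known", "first", "only" and "open" are said of these compounds alone.

Going by the values given here, compound 2 `CCC(C(=O)N1CCN(c2ccccc2F)CC1)N1C(=O)CCC1=O` stands lowest of the two numbers so far: in a functional assay on the whole organism (strain Swiss) with Mus musculus as the target, in the maximal electroshock model, with a stated time of 0.25 h, at a dose of 100 mg/kg by the intraperitoneal route (a lower number here means a weaker effect, a higher number a stronger effect of the compound at the dose given), compound 2 gives 0%, whereas compound 1 `CCC(C(=O)N1CCN(c2cccc(Cl)c2)CC1)N1C(=O)CCC1=O` gives 50%. Among the compounds with values here, the only measured step, a number 50 percentage points lower from compound 1 to compound 2 (beyond the scatter), swaps the whole aryl substituent at once, so it bears only loosely on the step to compound 3 `CCC(C(=O)N1CCN(c2ccccc2)CC1)N1C(=O)CCC1=O`, which differs from compound 2 thus: hydrogen in place of fluoro on an aromatic carbon. The read-out of compound 2 cannot fall further, so any movement is upward or none. Compound 3 is expected to give 20%, with a range of 0% to 55%. The expected step is a number 20 percentage points higher from compound 2 to compound 3 (beyond the scatter), a modest rise that may stay within the scatter.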

Compound 3, a percentage reported as activity, at one dose (the size of the read-out at that dose, not a potency): 25%
Compound 3: middle estimate off by 5 percentage points, on the low side; measured number inside the range.
By their numbers in this assay, from the lowest: compound 2; then compound 3; then compound 1.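

In this assay, hydrogen in place of fluoro gives a number 25 percentage points higher from compound 2 to compound 3 (beyond the scatter) and so the plain phenyl keeps a measurable read-out, while fluoro at this place, ortho to a large group, goes with a lower number. Hydrogen in place of chloro gives a number 25 percentage points lower from compound 1 to compound 3 (beyond the scatter) and so, against plain phenyl, the two halogen-bearing compounds move in opposite directions. No evidence on hand bears on the cause of either step. Halogen identity and ring place remain confounded, so 2-chlorophenyl and 3-fluorophenyl would be needed to separate them. Going by these compounds, whether a methoxy or methyl group behaves like either halogen also remains open.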